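This account rests on a few compounds, and the source may have more. Where it says the series, first, only, none or still open, it means among the compounds named here.

Compound 2 `CC1=C(C(=O)OCC(F)(F)F)C(c2ccsc2)NC(=O)N1` is one of three compounds built on the same core that were tested in an assay on HeLa cells for displacement of a labelled ligand from adenosine receptor A3 (Homo sapiens), read by radioligand binding, with a stated time of 180 min, tested at 1 uM; on this read-out higher numbers stand for more inhibition at the one concentration tested (going by the name of the read-out) and lower numbers for less inhibition. Compound 2 gives 1%, the lowest of the two single numbers there, while compound 1 `CC1=C(C(=O)OC(C(F)(F)F)C(F)(F)F)C(c2ccsc2)NC(=O)N1` gives 8%, so that a number 7 percentage points lower from compound 1 to compound 2 (within the scatter). Compound 3 `CC1=C(C(=O)OC(C)C(F)(F)F)C(c2ccsc2)NC(=O)N1` also sits low, with repeated entries of 2%; 1% (2 entries); (the several entries of compound 3 in this assay, 2%; 1% (2 entries)). Compound 4 `CC1=C(C(=O)OCC(F)(F)F)C(c2ccco2)NC(=O)N1` differs from compound 2 in one place: furan-2-yl in place of thiophen-3-yl on a saturated ring carbon. Within the data shown here, no measured step concerns a change of this kind; the one measured step, a number 7 percentage points lower from compound 1 to compound 2 (within the scatter), touches only the ester chain and stays within the scatter, and all three measured compounds sit near the bottom of the scale. For compound 4 the step of a number 2 percentage points higher from compound 2 to compound 4 (within the scatter) is therefore expected, nothing beyond the scatter. The estimate for compound 4 is 3%, ranging from -7% to 13%.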

Compound 4, a percentage reported as inhibition, at one concentration (the size of the read-out at that concentration, not a potency): 1%
Beside the measured number, compound 4's estimate is 2 percentage points above it; low and high end bracket the measured number.
By their numbers in this assay, from the lowest: compounds 2, 4 and 1 (each within the scatter of the next).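

In this assay, furan-2-yl in place of thiophen-3-yl on the saturated ring carbon gives no change at the digits printed from compound 2 to compound 4 (within the scatter). Among these compounds, the earlier step touched only the ester chain, so this is the first reading at this position: one five-membered aromatic ring with an oxygen in place of one with a sulfur, at a different attachment point, does not lift the number off the bottom of the scale. Nothing at hand bears on why this is so. With both compounds this low, the read-out says little about how much this position matters. From the compounds shown here alone, whether a longer chain, an amine or a carboxylic acid on this carbon would raise the number remains open.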